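A few compounds are considered here, and "the series" means these few. Any claim that something is new, unique, unknown or untested is made for them only; others in the source may bear on it.

Measured compounds in a functional assay on Malme-3M cells (Homo sapiens) for inhibition, read by sulforhodamine B assay, with a stated time of 48 h; a lower number here means a stronger inhibitor of growth, a higher number a weaker inhibitor of growth:
compound 1 `COc1ccc(-c2cc(/C=C/C(=O)c3ccc(N)cc3)[nH]n2)cc1` gives 6220 nM
compound 2 `COc1cc(-c2cc(/C=C/C(=O)c3ccc(N)cc3)[nH]n2)cc(OC)c1OC` gives 4710 nM
compound 3 `COc1ccc(C(=O)/C=C/c2cc(-c3cc(OC)c(OC)c(OC)c3)n[nH]2)cc1` gives 3850 nM

Compound 2 stands second highest of these three numbers; its nearest neighbour is compound 3, and its furthest is compound 1, and both of those gaps are within the scatter, so the three measured compounds are not separable in this assay.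

Compound 4 `COc1ccc(-c2cc(/C=C/C(=O)c3ccc(N)cc3)[nH]n2)cc1OC` is the next compound of the series. The change is hydrogen in place of methoxy on an aromatic carbon. Among the measured compounds shown here, no measured step matches this change. For the measured compounds named here, the one measured step, a 1.2-fold lower number from compound 2 to compound 3 (0.09 log units; within the scatter), concerns a different place on the molecule and lies within the scatter. Compound 1 and compound 2 differ in more than one place, and their two values also lie within the scatter of each other. Going by the values given here, nothing measured so far therefore points to a step beyond the scatter for the removal of a methoxy group, and none is expected.

The expected step is a 1.1-fold higher number from compound 2 to compound 4 (0.03 log units; within the scatter). For compound 4 the estimate in this assay is 5000 nM, with a range from 2500 nM to 10000 nM.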

Compound 4, concentration for total growth inhibition: 21200 nM
For compound 4 the middle estimate is 4.2-fold (0.63 log units) below the measured one; measured number above the stated range.
By their numbers in this assay, from the lowest: compounds 3, 2 and 1 (each within the scatter of the next); then compound 4.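

In this assay, among the compounds shown here, the methoxy group on this aromatic carbon, ortho to a methoxy group, meta to a methoxy group and meta to a large group, gives the first single change beyond the scatter: hydrogen in its place gives a 4.5-fold higher number from compound 2 to compound 4 (0.65 log units; beyond the scatter). Adding a methoxy group to compound 1 also raises the number, with a 3.4-fold higher number from compound 1 to compound 4 (0.53 log units; beyond the scatter), so compound 4 lies above both of its single-change neighbours and the number does not move in one direction with the count of methoxy groups across compound 1, compound 4 and compound 2. No measurement at hand accounts for this behaviour.

On these data alone, whether a hydroxyl group or a chlorine atom on this carbon would keep the number near that of compound 2 remains open. Also open, as far as these compounds go, is whether methoxy in place of amino would change the number on the ring pattern of compound 4.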